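Quaternary ammonium tail variations on a COL1A1 promoter series

A few compounds are considered here, and "the series" means these few. Any claim that something is new, unique, unknown or untested is made for them only; others in the source may bear on it.

Within the data shown here, compound 1 `Cc1cc(-n2cc(C(=O)Nc3cc(F)cc(F)c3)c(=O)c3ccc(N(C)C)nc32)ccc1OCCCCCCC[N+]12CCN(CC1)CC2` is the only member of this set with a number in an assay on LX2 cells for inhibition of COL1A1 promoter (Homo sapiens), read by a luciferase reporter, with a stated time of 24 h, tested at 20 uM; a lower number here means a weaker effect, a higher number a stronger effect of the compound at the concentration tested: compound 1 gives 10.6%, a small effect at the concentration tested. Two further compounds were run in the same assay but return no number. Compound 2 `CN(C)c1ccc2c(=O)c(C(=O)Nc3cc(F)cc(F)c3)cn(-c3ccc(OCCCCCCC[n+]4ccccc4)cc3Cl)c2n1` is reported in this assay as "not active" (no number reported). Compound 3 `CC[N+]1(CCCCCCCOc2ccc(-n3cc(C(=O)Nc4cc(F)cc(F)c4)c(=O)c4ccc(N(C)C)nc43)c(C)c2)CCCCC1` is likewise reported in this assay as "not active" (no number reported). Among the measured compounds shown here, no step between two measured compounds is available, so the size of change to be expected from altering the charged tail cannot be read from measured pairs.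

Compound 4 `CC[N+]1(CCCCCCCOc2ccc(-n3cc(C(=O)Nc4cc(F)cc(F)c4)c(=O)c4ccc(N(C)C)nc43)cc2C)CCCCC1` differs from compound 1 as follows: a group of 8 heavy atoms (7 carbon, 1 nitrogen; one six-membered non-aromatic ring with 1 hetero atom) in place of a group of 8 heavy atoms (6 carbon, 2 nitrogen; 2 six-membered non-aromatic rings with 2 hetero atoms each), on a saturated chain carbon, seven bonds along the chain from an oxygen on an aromatic ring. Compound 3 carries the same entering group as compound 4 and is not active, while compound 1 itself sits low; the step from compound 1 to compound 4 is therefore expected to be small, downward or none beyond the scatter, a number 5.6 percentage points lower from compound 1 to compound 4 (within the scatter). For compound 4 the expected value in this assay is 5%, with a range from -8% to 18%, and a real chance that only "not active" is reported.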

Compound 4, a percentage reported as inhibition, at one concentration (the size of the read-out at that concentration, not a potency): 19.7%
For compound 4 the middle estimate is 14.7 percentage points below the measured one; the whole stated range lies below it.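

In this assay, among these compounds, the group with one six-membered non-aromatic ring in place of the group with 2 six-membered non-aromatic rings gives a number 9.1 percentage points higher from compound 1 to compound 4 (within the scatter), the first measured step at this position, so the two charged groups cannot be told apart in this read-out. The entering group does not settle the outcome on its own: compound 4 gives 19.7%, whereas compound 3, which carries the same group, gives "not active" (no number reported). No measured property bears on this result.

From the compounds shown here alone, it remains open whether a tertiary amine or a trimethylammonium group at the end of the chain would shift the read-out beyond the usual scatter. Going by these compounds, the effect of a shorter or longer chain between the oxygen and the charged group also remains open.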